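Thiophene dihydropyrimidinone ester series: carbonyl substituent variation

A few compounds are considered here, and "the series" means these few. Any claim that something is new, unique, unknown or untested is made for them only; others in the source may bear on it.

Measured so far in an assay on membranes from CHO cells for displacement of a labelled ligand from adenosine receptor A1 (Homo sapiens), read by scintillation counting, with a stated time of 60 min, tested at 1 uM; on this read-out higher numbers stand for more inhibition at the one concentration tested (going by the name of the read-out) and lower numbers for less inhibition:
Compound 1 `CC1=C(C(=O)OCc2ccccc2)C(c2ccsc2)NC(=O)N1`: 57%
Compound 2 `CC1=C(C(N)=O)C(c2ccsc2)NC(=O)N1`: 2%
Compound 3 `CC1=C(C(=O)SC(C)C)C(c2ccsc2)NC(=O)N1`: 24%

Compound 3 stands second highest of the three numbers in this assay; its nearest neighbour is compound 2, whose value in this assay is 2%, and the furthest is compound 1, whose value in this assay is 57%. Going by the values given here, the one step that has been measured at the carbonyl carbon is a number 22 percentage points higher from compound 2 to compound 3 (beyond the scatter), which runs from the amide to the thioester. Compound 1 and compound 3 are not linked by a measured step; their two values simply show the benzyl ester above the thioester by a margin beyond the scatter.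

Compound 4 `CCC(CC)OC(=O)C1=C(C)NC(=O)NC1c1ccsc1` is not yet measured. The change from compound 3 is (pentan-3-yl)oxy in place of isopropylsulfanyl on a carbonyl carbon. It keeps a branched substituent of similar kind while returning to an oxygen-linked ester, as in compound 1. The step from compound 2 to compound 3 bears on it only indirectly, and the values of compound 1 and compound 3 suggest the oxygen ester side sits higher. A rise in this assay is therefore expected, estimated as a number 16 percentage points higher from compound 3 to compound 4 (beyond the scatter). For compound 4 the expected value is 40%, within a range of 15% to 65%.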

Compound 4, a percentage reported as inhibition, at one concentration (the size of the read-out at that concentration, not a potency): 22%
Estimate against measurement, compound 4: 18 percentage points above; the range from low to high includes it.
By their numbers in this assay, from the lowest: compound 2; then compounds 4 and 3 (each within the scatter of the next); then compound 1.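

In this assay, returning to an oxygen-linked ester at this carbonyl carbon does not by itself restore the higher read-out: a number 2 percentage points lower from compound 3 to compound 4 (within the scatter), while a number 35 percentage points lower from compound 1 to compound 4 (beyond the scatter), with the ester oxygen kept and only the group on it changed, so the identity of that group clearly counts. The amide still stands apart from this ester, with a number 20 percentage points higher from compound 2 to compound 4 (beyond the scatter), a step that sits alongside a number 22 percentage points higher from compound 2 to compound 3 (beyond the scatter) and places the amino group below both (pentan-3-yl)oxy and isopropylsulfanyl on this carbonyl carbon. No measured evidence is available to explain any of these differences.

From the compounds shown here alone, whether the higher value of compound 1 goes with the phenyl ring of its benzyl group remains open, and a phenethyl ester or a cyclohexylmethyl ester on the same carbonyl carbon would bear on that question. The sulfur and oxygen links are also seen here only with different groups attached to them, so an isopropyl ester or a benzyl thioester would give the direct comparison.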